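A few compounds are considered here, and "the series" means these few. Any claim that something is new, unique, unknown or untested is made for them only; others in the source may bear on it.

Measured so far in a functional assay on the whole organism with Mus musculus as the target; a higher number here means that more compound is needed for the effect, a lower number that less compound is needed:

Compound 1, `CN(C)C(=O)Cn1c(-c2ccc(F)cc2)nc2cccnc21`, gives 40.5 mg/kg.
Compound 2, `Cc1ccc(-c2nc3cccnc3n2CC(=O)N(C)C)cc1`, gives 4.7 mg/kg.
Compound 3, `CCCN(CCC)C(=O)Cn1c(-c2ccc(Cl)cc2)nc2cccnc21`, gives 11 mg/kg.

Compound 3 holds the second highest of these three numbers, with compound 2 nearest to it and compound 1 furthest away. Going by the values given here, the only measured step, an 8.6-fold lower number from compound 1 to compound 2 (0.94 log units; beyond the scatter), comes from a methyl in place of a fluoro on an aromatic carbon. Among the compounds with values here, compound 1 and compound 3 differ in two places at once, so their two values show only that compound 3 needs less compound than compound 1.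

Compound 4, `CN(C)CCNC(=O)Cn1c(-c2ccc(Cl)cc2)nc2cccnc21`, keeps the core of compound 3 and changes the group on the carbonyl carbon: (2-(dimethylamino)ethyl)amino in place of dipropylamino on a carbonyl carbon. Within the data shown here, no measured step touches that part of the molecule; the single known step concerns an aromatic carbon and cannot be carried over to the carbonyl carbon. The expectation therefore rests on compound 3 alone, with a wide margin to allow for an unknown effect in either direction. Compound 4 is expected to give 12 mg/kg, within 4 mg/kg to 36 mg/kg, which means an expected step of a 1.1-fold higher number from compound 3 to compound 4 (0.04 log units; within the scatter), that is, no change beyond the scatter.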

Compound 4, dose for half-maximal effect: 62 mg/kg
Beside the measured number, compound 4's estimate is 5.2-fold (0.71 log units) below it, outside the stated range (above it).
By their numbers in this assay, from the lowest: compound 2; then compound 3; then compounds 1 and 4 (each within the scatter of the next).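

In this assay the group on the carbonyl carbon proves able to shift the dose needed: with the rest of compound 3 unchanged, replacing dipropylamino with (2-(dimethylamino)ethyl)amino gives a 5.6-fold higher number from compound 3 to compound 4 (0.75 log units; beyond the scatter). This swap alters several features at once, since the entering group differs from the one leaving in its nitrogen count and its hydrogen-bond donor and acceptor counts, so the step cannot be assigned to any single feature. No measurement available here explains the increase.

The compounds shown leave open whether the higher dose goes with the amide hydrogen or with the dimethylamino end of the chain; a plain propylamino group on the carbonyl carbon would keep that hydrogen without the second amine, and would help separate the two. A ring amine such as piperidine or morpholine, or a carboxylic acid at the end of the chain, would show how other groups at this carbonyl carbon compare with dipropylamino.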